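This account rests on a few compounds, and the source may have more. Where it says the series, first, only, none or still open, it means among the compounds named here.

In a functional assay on CEM-DNR-bulk cells (Homo sapiens), read by MTT assay, with a stated time of 72 h (a higher number here means a weaker inhibitor, a lower number a stronger inhibitor), compound 1 `Cc1nc(N)c2c(-c3ccco3)cn([C@@H]3O[C@H](CO)[C@@H](O)[C@H]3O)c2n1` gives > 20000 nM, which is a limit of the assay and not a number. Compound 2 `Nc1nc2c(c(-c3ccco3)cn2[C@@H]2O[C@H](CO)[C@@H](O)[C@H]2O)c(=O)[nH]1` gives > 20000 nM, again a limit and not a number. The numbers therefore set no order between these two compounds, and what they share is the limit of > 20000 nM in this assay, at which 2 of the 2 values shown sit.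

Compound 3 `Nc1nc2c(c(-c3ccccc3)cn2[C@@H]2O[C@H](CO)[C@@H](O)[C@H]2O)c(=O)[nH]1` keeps the core of compound 2 but carries phenyl in place of furan-2-yl on an aromatic carbon. For the measured compounds named here, no pair of measured compounds differs in one place only, so the data show no direct precedent for this swap. The expected change a number no higher from compound 2 to compound 3 (the limit leaves the size open) is none beyond the usual scatter. This expectation rests only on compound 2, whose limit of > 20000 nM gives no sign of measurable activity. For compound 3 the estimated value is 20000 nM, with an expected range from 8000 nM to 30000 nM.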

Compound 3, half-maximal inhibitory concentration: > 20000 nM
Compound 3: a limit, no number; the forecaster's own chance of this, stated with the estimate: 85%; the middle value sits exactly at the limit.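

Compound 2 and compound 3 both sit at a limit of the assay, not at a number, so phenyl in place of furan-2-yl gives no readable step between them. The compounds shown leave open whether any group at this place brings measurable activity in this assay.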